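This account rests on a few compounds, and the source may have more. Where it says the series, first, only, none or still open, it means among the compounds named here.

Compound 1 `CCN1CCN(Cc2ccc(NC(=O)c3ccc(C)c(C#Cc4cccnc4)c3)cc2C(F)(F)F)CC1` is the starting point of this comparison. Among the measured compounds shown here, in a functional assay on BaF3 cells (Mus musculus) for antiproliferative activity (a lower number here means that less compound is needed, a higher number that more compound is needed for the effect), compound 1 gives 1590 nM, the highest of the two numbers measured so far, so among the measured compounds it needs the most material for the effect. For the measured compounds named here, its only measured neighbour is compound 2 `CCN1CCN(Cc2ccc(NC(=O)c3ccc(C)c(C#Cc4cnc5[nH]cnc5c4)c3)cc2C(F)(F)F)CC1`, which in this assay gives 60 nM; the step of a 27-fold lower number from compound 1 to compound 2 (1.42 log units; beyond the scatter) came from exchanging the pyridin-3-yl on the triple-bonded carbon for a larger group of 9 heavy atoms built from a five-membered aromatic ring with 2 hetero atoms fused to a six-membered aromatic ring with 1 hetero atom.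

Compound 3 `CCN1CCN(Cc2ccc(NC(=O)c3ccc(C)c(C#Cc4cnc5nccnc5c4)c3)cc2C(F)(F)F)CC1` has not yet been measured. It differs from compound 1 at the same place: a group of 10 heavy atoms (7 carbon, 3 nitrogen; one six-membered aromatic ring with 1 hetero atom, one six-membered aromatic ring with 2 hetero atoms) in place of a group of 6 heavy atoms (5 carbon, 1 nitrogen; one six-membered aromatic ring with 1 hetero atom), on a triple-bonded carbon. Going by the values given here, the one step that bears on this change, from compound 1 to compound 2, was large and in the direction of a lower number, and it also replaced the pyridin-3-yl with a fused two-ring group on that triple-bonded carbon. A step of similar direction but less certain size is therefore expected, an 11-fold lower number from compound 1 to compound 3 (1.03 log units; beyond the scatter). For compound 3 the estimate in this assay is 150 nM, within a range from 40 nM to 600 nM.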

Compound 3, half-maximal effective concentration: 3320 nM
Compound 3: middle estimate off by 22-fold (1.35 log units), on the low side; the whole stated range lies below it.
By their numbers in this assay, from the lowest: compound 2; then compound 1; then compound 3.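

A second ring on the triple-bonded carbon does not by itself bring the number down in this assay: replacing pyridin-3-yl with the group of two six-membered aromatic rings gives a 2.1-fold higher number from compound 1 to compound 3 (0.32 log units; beyond the scatter) and so runs opposite to the earlier step, which had pointed to a clear gain. The two fused groups also stand far apart, with a 55-fold higher number from compound 2 to compound 3 (1.74 log units; beyond the scatter) for a swap that leaves the number of rings unchanged, so among these three compounds the number does not simply follow ring count: compound 2 has the low number, while compound 3, with the same count, lies on the far side of compound 1. No available measurement accounts for this wide gap between two such similar groups.

Among the compounds shown here, with only three groups at this position, it remains open how much of the low number of compound 2 belongs to its five-membered ring and how much to the fused group as a whole. From the compounds shown here alone, it is also open whether a simpler change, such as an amine on the pyridin-3-yl, would move the number in the same direction as the step to compound 2.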